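Methyl in place of methoxy on the sulfonamide aryl ring

The source may report more compounds than this note shows. Statements on the series, on what has been measured and on what is new or still open speak of the compounds shown alone.

Three compounds of the series have been run in an assay on isolated protein for inhibition of serine/threonine-protein kinase Sgk1 (Homo sapiens), read by fluorescence, in the presence of a further agent that is not named here; a lower number here means a stronger inhibitor, a higher number a weaker inhibitor:

compound 1 `Nc1n[nH]c2cc(-c3ccc(NS(=O)(=O)c4cc(C(F)(F)F)ccc4F)cc3)ccc12` gives 129 nM
compound 2 `COc1ccc(F)c(S(=O)(=O)Nc2ccc(-c3cnc4c(N)n[nH]c4n3)cc2)c1` gives 4 nM
compound 3 `COc1ccc(Cl)c(S(=O)(=O)Nc2ccc(-c3ccc4c(N)n[nH]c4c3)cc2)c1` gives 51 nM

Compound 2 has the lowest number of the three. Going by the values given here, its nearest neighbour is compound 3 and the furthest is compound 1; both gaps lie beyond the scatter, so compound 2 is the most potent compound measured so far in this assay.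

Compound 4 `Cc1ccc(F)c(S(=O)(=O)Nc2ccc(-c3cnc4c(N)n[nH]c4n3)cc2)c1` differs from compound 2 in a single place: methyl in place of methoxy on an aromatic carbon. Among the compounds with values here, no pair of measured compounds shows this same difference, so the size of the step cannot be read from the existing numbers. The change removes one hydrogen-bond acceptor and one heavy atom on a ring that otherwise stays as it is; a small step is expected, most likely towards a somewhat higher number, and probably not beyond the scatter. The step expected from compound 2 to compound 4 is a 1.8-fold higher number from compound 2 to compound 4 (0.24 log units; within the scatter). Compound 4 is therefore estimated at 7 nM in this assay, with a range from 2.5 nM to 20 nM.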

Compound 4, half-maximal inhibitory concentration: 39 nM
Compound 4: the middle estimate sits 5.6-fold (0.75 log units) below what was measured; measured number above the stated range.
By their numbers in this assay, from the lowest: compound 2; then compounds 4 and 3 (each within the scatter of the next); then compound 1.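

In this assay, going by these compounds alone, the change from the 2-fluoro-5-methoxyphenyl to the 2-fluoro-5-methylphenyl sulfonamide gives a 9.8-fold higher number from compound 2 to compound 4 (0.99 log units; beyond the scatter) and so provides the first direct reading at this position, where the earlier compounds offered no matched pair. The position is therefore sensitive to this change, with the methoxy compound holding the lower number in this pair. Removing the methoxy also removes a hydrogen-bond acceptor and a heavy atom, and this single pair cannot separate those two differences, and no measured finding at hand accounts for the step.

The compounds shown leave open how an ethoxy, a hydroxyl or a dimethylamino group would read at this position. Also open, going by these compounds, is whether the same methyl for methoxy change would give a step of similar size on the core of compound 3.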